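Branching the Alkyl on the Pyrimidine: Propyl to tert-Butyl

The source may report more compounds than this note shows. Statements on the series, on what has been measured and on what is new or still open speak of the compounds shown alone.

Measured compounds:
compound 1 `Cc1ncc(-c2nc(C(F)(F)F)sc2N2CCN(C(=O)Cn3nc(C)nc3C)[C@H](C)C2)cn1` — 19 nM
compound 2 `CCCc1ncc(-c2nc(C(F)(F)F)sc2N2CCN(C(=O)Cn3nc(C)nc3C)[C@H](C)C2)cn1` — 4.4 nM

In a functional assay on CHO-K1 cells for antagonist activity at C-X-C chemokine receptor type 3 (Homo sapiens), read by FLIPR, with a stated time of 10 min (on this read-out higher numbers stand for weaker inhibition and lower numbers for stronger inhibition), compound 2 gives 4.4 nM, the lower of the two numbers recorded; its nearest neighbour is compound 1, which in this assay gives 19 nM. For the measured compounds named here, the only measured step, a 4.3-fold lower number from compound 1 to compound 2 (0.64 log units; beyond the scatter), arose from ethyl in place of hydrogen on a saturated chain carbon bound to an aromatic carbon.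

Compound 3 `Cc1nc(C)n(CC(=O)N2CCN(c3sc(C(F)(F)F)nc3-c3cnc(C(C)(C)C)nc3)C[C@H]2C)n1` is not yet measured. It differs from compound 2 by tert-butyl in place of propyl on an aromatic carbon, a change that is tert-butyl in place of propyl on an aromatic carbon of a six-membered aromatic ring with two nitrogen, between two ring nitrogen atoms. Going by the values given here, the step from compound 1 to compound 2 bears on this only loosely: it shows that lengthening the chain at this carbon helped, but it says nothing about branching, and no measured pair addresses a branched group here. Compound 3 is therefore expected to sit close to compound 2, with a 1.0-fold higher number from compound 2 to compound 3 (0.01 log units; within the scatter) likely within the scatter in either direction. Compound 3 is estimated at 4.5 nM, with a range from 1.5 nM to 14 nM.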

Compound 3, half-maximal inhibitory concentration: 8.7 nM
Estimate against measurement, compound 3: 1.9-fold (0.29 log units) below; low and high end bracket the measured number.
By their numbers in this assay, from the lowest: compounds 2 and 3 (each within the scatter of the next); then compound 1.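

In this assay, for the compounds shown here, the result gives the first reading of a branched group at this carbon, and the step of a 2.0-fold higher number from compound 2 to compound 3 (0.30 log units; within the scatter) places tert-butyl level with propyl, so that the two groups cannot be told apart on this read-out. The step of a 2.2-fold lower number from compound 1 to compound 3 (0.34 log units; beyond the scatter) shows that tert-butyl also stands apart from methyl, which means that the gain over methyl seen with propyl is not limited to the straight chain among these three compounds. Since the larger group, with its four carbon atoms on the aromatic carbon between the two ring nitrogen atoms, keeps the number within the scatter of the propyl compound, this carbon accepts both a straight and a fully branched alkyl group in this series, but no other kind of measurement accompanies these numbers and nothing shown explains them.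

The compounds shown leave open how isopropyl, cyclopropyl or a longer chain such as butyl would read at this carbon, and so whether any alkyl group here would go clearly beyond propyl and tert-butyl. They also leave open whether a group carrying oxygen or nitrogen, such as methoxy or an amine, would hold the number reached by these two alkyl groups.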